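This account rests on a few compounds, and the source may have more. Where it says the series, first, only, none or still open, it means among the compounds named here.

Compound 1 `O=C(Nc1ccccn1)c1cccc(Nc2ncc(F)c(Nc3ccc(F)cc3)n2)c1` gives 15300 nM in a functional assay on A549 cells (Homo sapiens) for antiproliferative activity, read by sulforhodamine B assay, with a stated time of 3 days; on this read-out lower numbers stand for stronger inhibition of growth and higher numbers for weaker inhibition of growth.
Compound 2 `O=C(Nc1nccs1)c1cccc(Nc2ncc(F)c(Nc3ccc(F)cc3)n2)c1` gives in this assay only a limit, > 10000 nM.
Compound 3 `O=C(Nc1cccc(Nc2ncc(F)c(Nc3ccc(F)cc3)n2)c1)c1cnccn1` gives 10300 nM in this assay.

Of the two numbers shown, compound 1 has the highest; the nearest is a 1.5-fold lower number from compound 1 to compound 3 (0.17 log units; within the scatter), which lies within the scatter. Compound 2 sits at the assay limit (the limit of > 10000 nM in this assay, at which 1 of the 3 values shown sits), so the step that the limit leaves unreadable from compound 1 to compound 2 cannot be read. Compound 4 `O=C(Nc1cccc(Nc2ncc(F)c(Nc3ccc(F)cc3)n2)c1)c1ccncc1` differs from compound 1 as follows: ((pyridin-4-yl)carbonyl)amino in place of (pyridin-2-yl)carbamoyl on an aromatic carbon. The measured step that bears most on this is a 1.5-fold lower number from compound 1 to compound 3 (0.17 log units; within the scatter), where a carbamoyl group on the same aromatic carbon is likewise exchanged for a carbonylamino group, with no movement beyond the scatter. Compound 4 is therefore expected to show no step beyond the scatter in this assay, an estimated 1.3-fold lower number from compound 1 to compound 4 (0.11 log units; within the scatter). Compound 4 is expected to give 12000 nM, in the range 5000 nM to 30000 nM.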

Compound 4, concentration for 50% growth inhibition: 1650 nM
For compound 4 the middle estimate is 7.3-fold (0.86 log units) above the measured one; the whole stated range lies above it.
By their numbers in this assay, from the lowest: compound 4; then compounds 3 and 1 (each within the scatter of the next).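

In this assay, the exchange at this aromatic carbon is no longer neutral: ((pyridin-4-yl)carbonyl)amino in place of (pyridin-2-yl)carbamoyl gives a 9.3-fold lower number from compound 1 to compound 4 (0.97 log units; beyond the scatter), although the earlier exchange for a carbonylamino group stayed within the scatter. With that link kept, pyridin-4-yl in place of pyrazin-2-yl gives a 6.2-fold lower number from compound 3 to compound 4 (0.80 log units; beyond the scatter), so the link alone does not set the level. Compound 2 gives only a limit, so an at least 6.0-fold lower number from compound 2 to compound 4 (0.78 log units; beyond the scatter) is a bound, and the steps from compound 1 to compound 2 and from compound 2 to compound 3 cannot be read: the limit of > 10000 nM in this assay, at which 1 of the 4 values shown sits.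

As far as these compounds go, it remains open whether a pyridin-3-yl ring, a phenyl ring or an aminomethyl group on the carbonyl would hold this level in this assay.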